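Arylpiperazine oxazoles: expected effect of ring substituent swap

A few compounds are considered here, and "the series" means these few. Any claim that something is new, unique, unknown or untested is made for them only; others in the source may bear on it.

Measured compounds:
compound 1 `CCCc1nc(-c2ccccc2)c(CNCCCN2CCN(c3cccc(Cl)c3)CC2)o1` 65.9%
compound 2 `CCCc1nc(-c2ccccc2)c(CNCCN2CCN(c3ccc(OC)cc3)CC2)o1` 51.5%
compound 3 `CCCc1nc(-c2ccccc2)c(CNCCN2CCN(c3ccccc3)CC2)o1` 54.3%

In an assay on HEK293 cells for inhibition of Voltage-dependent T-type calcium channel subunit alpha-1G (Homo sapiens), read by fluorescence, tested at 10 uM (a higher number here means more inhibition at the concentration tested (going by the name of the read-out), a lower number less inhibition), compound 1 gives the highest of the three numbers; compound 3 sits below it by a margin beyond the scatter, and compound 2 lies further below, also beyond the scatter. Neither compound 2 nor compound 3 differs from compound 1 in one place only, so no single step can be read off from those gaps.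

Compound 4 `CCCc1nc(-c2ccccc2)c(CNCCCN2CCN(c3ccccc3C)CC2)o1` has not yet been measured. It differs from compound 1 in one place: 2-methylphenyl in place of 3-chlorophenyl on an amine nitrogen in a ring.

Going by the values given here, the only measured single step changes the group on the same ring nitrogen: a number 2.8 percentage points higher from compound 2 to compound 3 (within the scatter), a change within the scatter. That step bears on the change from compound 1 to compound 4, since both replace one aromatic ring substituent with another on the same position, although neither chlorine nor methyl is covered by a measured pair. Among the compounds with values here, on that basis no step beyond the scatter is expected in this assay for compound 4 in either direction, with the caveat that only one such step is available.

Compound 4 is therefore expected to give 61%, with a range from 46% to 76%, meaning an estimated step of a number 4.9 percentage points lower from compound 1 to compound 4 (within the scatter).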

Compound 4, a percentage reported as inhibition, at one concentration (the size of the read-out at that concentration, not a potency): 54.5%
Beside the measured number, compound 4's estimate is 6.5 percentage points above it; low and high end bracket the measured number.
By their numbers in this assay, from the lowest: compounds 2, 3 and 4 (each within the scatter of the next); then compound 1.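

In this assay, going by these compounds alone, 2-methylphenyl in place of 3-chlorophenyl on an amine nitrogen in a ring gives a number 11.4 percentage points lower from compound 1 to compound 4 (beyond the scatter) and is the first single change to go beyond the scatter, whereas the only earlier step on this ring nitrogen was a number 2.8 percentage points higher from compound 2 to compound 3 (within the scatter) in the same read-out. The aryl group at this position is therefore not freely interchangeable, even though the two groups match in heavy-atom count and neither has hydrogen-bond donors or acceptors, and the swap alters both the substituent and its place on the phenyl ring. Nothing measured here accounts for the size or direction of this step.

The step cannot yet be divided between the change of chlorine to methyl and the change of ring position, and 3-methylphenyl or 2-chlorophenyl on the same chain would separate the two. Whether a longer or shorter chain to the ring nitrogen changes the read-out also stays open, as no pair shown differs in the chain alone.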